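A few compounds are considered here, and "the series" means these few. Any claim that something is new, unique, unknown or untested is made for them only; others in the source may bear on it.

Compound 1 `C=CC(C)(O)CC[C@@H]1C(=C)CC[C@H](Br)[C@@]1(C)CCC(O)C(C)(C)Cl`: 94100 nM
Compound 2 `C=CC(C)(O)CC[C@@H]1C(=C)CC[C@H](Br)[C@@]1(C)CCC1OC1(C)C`: > 100000 nM

Among the compounds with values here, in a functional assay on A549 cells (Homo sapiens) for cytotoxicity, read by MTT assay, with a stated time of 48 h (a higher number here means a weaker inhibitor, a lower number a stronger inhibitor), compound 1 carries the only actual number, 94100 nM. Compound 2 reads > 100000 nM, which is a limit. Compound 3 `C=CC(C)(O)CC[C@@H]1C(=C)CC[C@H](Br)[C@@]1(C)CCC(=O)C(C)C` differs from compound 1 as follows: isopropylcarbonyl in place of 2-chloro-1-hydroxy-2-methylpropyl on a saturated chain carbon, two bonds along the chain from a saturated ring carbon. Within the data shown here, the same group leaves in the one measured step, to compound 2, and that step is an at least 1.0-fold higher number from compound 1 to compound 2 (0.02 log units; that floor lies within the scatter). It therefore offers no sign of a real shift, and no change beyond the scatter is expected in this assay. The expected step is a 1.1-fold lower number from compound 1 to compound 3 (0.04 log units; within the scatter). For compound 3, the half-maximal inhibitory concentration is estimated at 85000 nM, within a range of 35000 nM to 150000 nM.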

Compound 3, half-maximal inhibitory concentration: > 100000 nM
Compound 3: a limit, no number; the forecaster's own chance of this, stated with the estimate: 45%; middle value at least 1.1-fold (0.07 log units) from the limit.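

In this assay compound 3 reads > 100000 nM, which is a limit and not a number. Isopropylcarbonyl at this place gives an at least 1.0-fold higher number from compound 1 to compound 3 (0.02 log units; that floor lies within the scatter), so a second, different replacement of 2-chloro-1-hydroxy-2-methylpropyl also shows no readable shift beyond the scatter, and it gives no lower number; the step between compound 2 and compound 3 cannot be read. The two replacements end alike: the limit of > 100000 nM in this assay, at which 2 of the 3 values shown sit.

Going by these compounds, how far compound 2 and compound 3 truly lie from compound 1 stays open. Also open, on these data alone, is whether an amine or a carboxylic acid on this saturated chain carbon would give a readable number.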